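Series notes: cell growth inhibition, step to compound 4

The compounds below may be only part of what the source reports. "The series", "measured", "known", "first", "only" and "open" are said of these compounds alone.

Measured compounds:
Compound 1, `Cc1cc(Nc2cc(-c3ccccc3)[nH]n2)n2nc(SCc3cccc(Br)c3)nc2n1`, gives 4820 nM.
Compound 2, `Cc1cc(Nc2cc(-c3cccs3)[nH]n2)n2nc(SCc3ccc(Br)cc3)nc2n1`, gives 3770 nM.
Compound 3, `Cc1cc(Nc2cc(-c3ccccc3)[nH]n2)n2nc(SCc3cccc4ccccc34)nc2n1`, gives 3120 nM.

All three were run in a functional assay on MGC-803 cells (Homo sapiens) for inhibition, read by MTT assay, with a stated time of 72 h; on this read-out lower numbers stand for stronger inhibition and higher numbers for weaker inhibition. On the bare numbers compound 2 sits with compound 1 and compound 3 inside the usual scatter: its gap to compound 3 and its gap to compound 1 are both too small to separate the compounds, so the three values count as one level.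

Compound 4, `Cc1cc(Nc2cc(C(C)(C)C)[nH]n2)n2nc(SCc3ccc(Br)cc3)nc2n1`, differs from compound 2 in one place: tert-butyl in place of thiophen-2-yl on an aromatic carbon. Among the measured compounds shown here, the one measured step, a 1.5-fold lower number from compound 1 to compound 3 (0.19 log units; within the scatter), concerns the group on the saturated chain carbon bound to a sulfur, a different part of the shared core, and it stayed within the scatter. For the measured compounds named here, no measured step alters the group on the aromatic carbon where compound 4 differs from compound 2, so there is no direct precedent for exchanging a five-membered aromatic ring for a branched chain at that site.

Given that the only observed exchange of a peripheral group left this assay unchanged, the step of a 1.1-fold higher number from compound 2 to compound 4 (0.03 log units; within the scatter) is expected to stay within the scatter. Compound 4 is estimated at 4000 nM, with a range from 1500 nM to 11000 nM.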

Compound 4, half-maximal inhibitory concentration: 5620 nM
The estimate for compound 4 lay 1.4-fold (0.15 log units) below the measured number; the range from low to high includes it.
By their numbers in this assay, from the lowest: compounds 3, 2, 1 and 4 (each within the scatter of the next).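

In this assay, among the compounds shown here, this is the first direct reading of a change on the aromatic carbon of the five-membered aromatic ring with 2 nitrogen: a 1.5-fold higher number from compound 2 to compound 4 (0.17 log units; within the scatter), with tert-butyl in place of thiophen-2-yl. At this place, then, a five-membered aromatic ring with 1 hetero atom and its hydrogen-bond acceptor can give way to a group with no ring and no hydrogen-bond acceptor without a change that can be separated from the scatter, although this single pair cannot define the limits of what the position accepts. No accompanying measurement bears on this outcome or offers an account of it.

The compounds shown leave open whether an amine, a carboxylic acid or a longer chain such as n-hexyl on this aromatic carbon would move the number beyond the scatter. They also leave open whether the exchange of thiophen-2-yl for tert-butyl would read the same with 3-bromophenyl or naphthalen-1-yl on the saturated chain carbon bound to a sulfur.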